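Anilide series: the step from compound 2 to compound 3

This account rests on a few compounds, and the source may have more. Where it says the series, first, only, none or still open, it means among the compounds named here.

Measured so far:
compound 1 `Cc1cccc(NC(=O)c2cc3ccccc3oc2=O)c1` — 14500 nM in an in vitro assay on BTI-TN-5B1-4 cells for inhibition of Amine oxidase [flavin-containing] A (Homo sapiens), read by fluorescence; a lower number here means a stronger inhibitor, a higher number a weaker inhibitor
compound 2 `CCc1ccc(NC(=O)c2cc3ccccc3oc2=O)cc1` — 15700 nM in this assay

Compound 2 holds the higher of the two numbers; its nearest neighbour is compound 1, whose number lies lower by a margin within the usual scatter, so the two read as one level. Compound 3 `O=C(Cl)c1ccc(NC(=O)c2cc3ccccc3oc2=O)cc1` differs from compound 2 thus: a group of 3 heavy atoms (1 carbon, 1 oxygen, 1 chlorine; no ring) in place of a group of 2 heavy atoms (2 carbon; no ring), on an aromatic carbon. Among the measured compounds shown here, no step between measured compounds covers this change, so the series itself gives no direction. The step of a 1.0-fold lower number from compound 2 to compound 3 (0.02 log units; within the scatter) is expected to stay within the scatter. Compound 3 is therefore estimated at 15000 nM, with a range from 5000 nM to 45000 nM.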

Compound 3, half-maximal inhibitory concentration: 9670 nM
Beside the measured number, compound 3's estimate is 1.6-fold (0.19 log units) above it; the range from low to high includes it.
By their numbers in this assay, from the lowest: compounds 3, 1 and 2 (each within the scatter of the next).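

In this assay, exchanging ethyl for a carbonyl chloride group on this aromatic carbon, para to a large group, adds 1 hydrogen-bond acceptor yet gives a 1.6-fold lower number from compound 2 to compound 3 (0.21 log units; within the scatter). This position therefore accepts a group with a double bond outside aromatic rings and 1 hydrogen-bond acceptor without a step beyond the scatter. Nothing available bears on the cause of this result.

Still open, as far as these compounds go, is whether an amine, a carboxylic acid or a longer chain at this position would give a step beyond the scatter. The effect of the carbonyl chloride group elsewhere on the ring also remains unresolved.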